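Series notes: compound 4 by way of compound 3

A few compounds are considered here, and "the series" means these few. Any claim that something is new, unique, unknown or untested is made for them only; others in the source may bear on it.

Measured so far in a functional assay on DU-145 cells (Homo sapiens) for inhibition, read by trypan blue exclusion, with a stated time of 96 h; a lower number here means a stronger inhibitor of growth, a higher number a weaker inhibitor of growth:
- compound 1 `O=C(/C(=C\c1ccc([N+](=O)[O-])c(O)c1)SCc1ccc(Br)cc1)c1ccc([N+](=O)[O-])c(Cl)c1`: 1000 nM
- compound 2 `O=C(O)c1ccc(C(=O)/C(=C\c2ccc(Br)cc2)SCc2ccc(Br)cc2)cc1`: 1000 nM
- compound 3 `CN(C)c1ccc(/C=C(/SCc2ccc(Br)cc2)C(=O)c2ccc(C(=O)O)cc2)cc1`: 50000 nM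

Compound 3 stands at the highest number of the three; its nearest neighbour is compound 1, and compound 2 stands as far away, both beyond the scatter. For the measured compounds named here, the one measured step in this assay, a 50-fold higher number from compound 2 to compound 3 (1.70 log units; beyond the scatter), is the change that brought the dimethylamino group in.

Compound 4 is `O=C(O)c1ccc(C(=O)/C(=C\c2ccc([N+](=O)[O-])c(O)c2)SCc2ccc(Br)cc2)cc1`. It differs from compound 3 thus: 3-hydroxy-4-nitrophenyl in place of 4-(dimethylamino)phenyl on a double-bonded chain carbon bound to a double-bonded chain carbon. The change removes the very group whose arrival in compound 3 gave the large rise. Going by the values given here, compound 1 carries the same 3-hydroxy-4-nitrophenyl on the chain and gives 1000 nM, and compound 2 with the carboxy-bearing ketone side gives 1000 nM; no step between those two is available, so only the two values themselves can be read.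

The expectation for compound 4 is therefore a large fall, a 33-fold lower number from compound 3 to compound 4 (1.52 log units; beyond the scatter), back to the level of compound 1 and compound 2. Compound 4 is estimated at 1500 nM, within 400 nM to 6000 nM.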

Compound 4, concentration for 50% growth inhibition: 10000 nM
Compound 4: middle estimate off by 6.7-fold (0.82 log units), on the low side, and the stated range ends below it.
By their numbers in this assay, from the lowest: compounds 1 and 2 (each within the scatter of the next); then compound 4; then compound 3.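

In this assay, 3-hydroxy-4-nitrophenyl on the double-bonded chain carbon recovers only part of the loss seen with 4-(dimethylamino)phenyl: a 5.0-fold lower number from compound 3 to compound 4 (0.70 log units; beyond the scatter) still leaves it short of 4-bromophenyl, as a 10-fold higher number from compound 2 to compound 4 (1.00 log units; beyond the scatter) shows. With 4-carboxyphenyl on the carbonyl carbon, this position now gives a three-step order from the lowest number: 4-bromophenyl, 3-hydroxy-4-nitrophenyl, then 4-(dimethylamino)phenyl. The group on the chain does not set the number alone, since a 10-fold higher number from compound 1 to compound 4 (1.00 log units; beyond the scatter) comes with 4-carboxyphenyl in place of 3-chloro-4-nitrophenyl on the carbonyl carbon while 3-hydroxy-4-nitrophenyl stays; nothing at hand explains any of these steps.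

Open, from the compounds shown here alone, is how a methyl ester or a primary amide would read in place of the carboxylic acid. Also open, going by these compounds, is where 4-aminophenyl or plain phenyl on the double-bonded chain carbon would fall in this order.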